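Switching the chloromethyl group for a propylamino group

The compounds below may be only part of what the source reports. "The series", "measured", "known", "first", "only" and "open" are said of these compounds alone.

Measured so far, in a functional assay on HT-1080 cells (Homo sapiens) for antiproliferative activity, read by sulforhodamine B assay, with a stated time of 48 h; on this read-out higher numbers stand for weaker inhibition and lower numbers for stronger inhibition:
compound 1 `CCCCCC(=O)Nc1ccc(S(=O)(=O)Oc2ccccc2C(C)C)cc1` gives 6300 nM
compound 2 `CC(C)C(=O)Nc1ccc(S(=O)(=O)Oc2ccccc2C(C)C)cc1` gives 4900 nM
compound 3 `CC(C)c1ccccc1OS(=O)(=O)c1ccc(NC(=O)CCl)cc1` gives 1000 nM

Compound 3 stands lowest of the three, and its steps to both others lie beyond the scatter, so it is the strongest inhibitor here: a 6.3-fold lower number from compound 1 to compound 3 (0.80 log units; beyond the scatter) and a 4.9-fold lower number from compound 2 to compound 3 (0.69 log units; beyond the scatter). The two larger alkyl groups hardly differ from each other: a 1.3-fold lower number from compound 1 to compound 2 (0.11 log units; within the scatter).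

Compound 4 `CCCNC(=O)Nc1ccc(S(=O)(=O)Oc2ccccc2C(C)C)cc1` is reached from compound 3 by the change (propylamino in place of chloromethyl on a carbonyl carbon); the same difference, cut one bond further out, reads (chloromethyl)carbonyl to propylcarbamoyl. Among the measured compounds shown here, no measured step introduces a propylamino group, so the only bearing steps are those that remove the chloromethyl group in favour of an alkyl chain, both modest and both in the direction of a higher number. Since compound 4 also loses that group, a step of similar size toward weaker inhibition is expected, a 5.0-fold higher number from compound 3 to compound 4 (0.70 log units; beyond the scatter). Compound 4 is therefore estimated at 5000 nM, within 1500 nM to 16000 nM.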

Compound 4, half-maximal inhibitory concentration: 680 nM
Beside the measured number, compound 4's estimate is 7.4-fold (0.87 log units) above it, outside the stated range (below it).
By their numbers in this assay, from the lowest: compounds 4 and 3 (each within the scatter of the next); then compounds 2 and 1 (each within the scatter of the next).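

In this assay, putting propylamino in place of chloromethyl on this carbonyl carbon gives no difference that can be told from the scatter (a 1.5-fold lower number from compound 3 to compound 4 (0.17 log units; within the scatter)). Among the compounds shown here, the chloromethyl group is therefore not the only group at this position that reaches this level, and the propylamino group also stands clear of both alkyl groups (a 7.2-fold lower number from compound 2 to compound 4 (0.86 log units; beyond the scatter); a 9.3-fold lower number from compound 1 to compound 4 (0.97 log units; beyond the scatter)). No data given here explain why the propylamino group differs from these alkyl groups.

Going by these compounds, it stays open whether the step away from the alkyl groups belongs to the nitrogen of the propylamino group or to its chain. A plain amino group, a dimethylamino group or a butylamino group on the same carbonyl carbon would help to separate these two parts.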